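The source may report more compounds than this note shows. Statements on the series, on what has been measured and on what is new or still open speak of the compounds shown alone.

Compound 1 `Cc1ccc(CS/C(=C/c2ccc(F)c(C)c2)C(=O)c2ccc(Cl)cc2)cc1`: 25000 nM
Compound 2 `CN(C)c1ccc(/C=C(/SCc2ccc(Cl)c(Cl)c2)C(=O)c2ccc(Cl)cc2)cc1`: 50000 nM

Both compounds were tested in a functional assay on DU-145 cells (Homo sapiens) for inhibition, read by trypan blue exclusion, with a stated time of 96 h; a lower number here means a stronger inhibitor of growth, a higher number a weaker inhibitor of growth. Compound 2 gives the higher of the two numbers, 50000 nM, but compound 1, at 25000 nM, lies within the usual scatter of it, so the two cannot be told apart. Both numbers sit in the same weak range.

The next compound to be measured is compound 3 `Cc1ccc(CS/C(=C/c2ccc(N(C)C)cc2)C(=O)c2ccc(Cl)cc2)cc1`. It differs from compound 2 by one change: 4-methylphenyl in place of 3,4-dichlorophenyl on a saturated chain carbon bound to a sulfur. In plain terms, 4-methylphenyl stands in place of 3,4-dichlorophenyl on a saturated chain carbon bound to a sulfur, so the 3,4-dichlorobenzyl group becomes 4-methylbenzyl.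

Within the data shown here, no two measured compounds differ in one place only, so the data hold no direct measure of this change. Among the measured compounds shown here, with only two close values to go on, no large shift in this assay is expected. The expected change is small, a 1.4-fold lower number from compound 2 to compound 3 (0.15 log units; within the scatter), and is not expected to go beyond the scatter. For compound 3 the estimated value is 35000 nM, with an expected range from 12000 nM to 80000 nM.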

Compound 3, concentration for 50% growth inhibition: > 100000 nM
Compound 3 was reported as a limit; the forecaster's own chance of this, stated with the estimate: 20%; middle value at least 2.8-fold (0.45 log units) from the limit.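

In this assay, compound 3 is reported only as a limit and not as a true number: the limit of > 100000 nM in this assay, at which 1 of the 3 values shown sits. Placing 4-methylphenyl where 3,4-dichlorophenyl stood, on a saturated chain carbon bound to a sulfur, gives an at least 2.0-fold higher number from compound 2 to compound 3 (0.30 log units; that floor lies within the scatter), so this floor alone cannot show that the change matters, although the real step may be larger. Among these compounds, the firmer reading comes from the other single change, 4-(dimethylamino)phenyl in place of 4-fluoro-3-methylphenyl on a double-bonded chain carbon bound to a double-bonded chain carbon, which gives an at least 4.0-fold higher number from compound 1 to compound 3 (0.60 log units; beyond the scatter); this is the first step beyond the scatter, and it shows that with the 4-methylbenzyl group held constant, the group at this position can shift growth inhibition towards weaker.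

From the compounds shown here alone, the true value of compound 3 remains unknown, so both steps have a lower bound but no measured size. The compounds shown leave open how an amine or a carboxylic acid on the benzyl ring, or a longer chain in place of the saturated chain carbon bound to a sulfur, would affect growth inhibition.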